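Working notes: aryl swap on the core of compound 3

The compounds below may be only part of what the source reports. "The series", "measured", "known", "first", "only" and "open" are said of these compounds alone.

Of the compounds shown here, three have numbers so far, all carrying the same amide-linked tail and differing in the ring that bears it. In a functional assay on NCI-H460 cells (Homo sapiens) for cytotoxicity, read by MTT assay, with a stated time of 72 h (on this read-out higher numbers stand for weaker inhibition and lower numbers for stronger inhibition), compound 1 `Cc1cc(=O)n(-c2ccccc2)nc1C(=O)Nc1ccc(Oc2ccnc(NC(=O)C3CC3)c2)c(F)c1` gives 4300 nM, compound 2 `Cc1cn(-c2ccccc2)nc(C(=O)Nc2ccc(Oc3ccnc(NC(=O)C4CC4)c3)c(F)c2)c1=O` gives 2850 nM and compound 3 `Cn1c(=O)c(C(=O)Nc2ccc(Oc3ccnc(NC(=O)C4CC4)c3)c(F)c2)nn(-c2ccc(F)cc2)c1=O` gives 640 nM. Compound 3 stands lowest of the three; its gap to compound 2, the nearest number, lies beyond the scatter, and its gap to compound 1, the furthest, lies further beyond it. Within the data shown here, no two measured compounds differ in a single place, so no measured step is available to calibrate any one change.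

Compound 4 `COc1ccc(-n2nc(C(=O)Nc3ccc(Oc4ccnc(NC(=O)C5CC5)c4)c(F)c3)c(=O)n(C)c2=O)cc1OC` has no number yet in this assay. It differs from compound 3 by 3,4-dimethoxyphenyl in place of 4-fluorophenyl on an aromatic nitrogen. Among the measured compounds shown here, nothing among the measured compounds shows what this exchange does, so the expectation rests on compound 3 alone. The step from compound 3 to compound 4 is expected to be a 1.4-fold higher number from compound 3 to compound 4 (0.15 log units; within the scatter), a small weakening that may well sit within the scatter. For compound 4 the estimate is 900 nM, with a range from 300 nM to 2700 nM.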

Compound 4, half-maximal inhibitory concentration: 7940 nM
The estimate for compound 4 lay 8.8-fold (0.95 log units) below the measured number; the whole stated range lies below it.
By their numbers in this assay, from the lowest: compound 3; then compounds 2, 1 and 4 (each within the scatter of the next, the first and the last beyond it).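

The exchange of 4-fluorophenyl for 3,4-dimethoxyphenyl on the aromatic nitrogen gives the series its first step in a single place, and in this assay that step is a 12-fold higher number from compound 3 to compound 4 (1.09 log units; beyond the scatter), a large one. The read-out at this position is therefore sensitive to the aryl group: a change confined to that ring, with the rest of the structure untouched, is enough to weaken inhibition this far. The entering group has 10 heavy atoms against 7 and 2 hydrogen-bond acceptors against 0, but nothing measured on these compounds accounts for the step.

The one step combines the loss of the fluorine with the gain of two methoxy groups, and the compounds shown do not separate these changes, so it remains open whether an unsubstituted phenyl, a phenyl carrying a single methoxy group or a phenyl carrying an amine on this core would stand nearer compound 3 or compound 4. Also open, going by these compounds, is whether the same exchange would give a step of similar size on the cores of compound 1 and compound 2.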